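The source may report more compounds than this note shows. Statements on the series, on what has been measured and on what is new or still open speak of the compounds shown alone.

In a functional assay on HL-60 cells (Homo sapiens) for inhibition, read by MTT assay, with a stated time of 72 h (on this read-out lower numbers stand for stronger inhibition and higher numbers for weaker inhibition), compound 1 `COc1cccc(N2CCN(C(=O)c3oc(C(F)(F)F)nc3-c3ccc(F)cc3)CC2)c1` gives "not active" (no number reported), with no number reported. For the measured compounds named here, compound 2 `CCc1nc(-c2cccc(F)c2)c(C(=O)N2CCN(c3cccc(OC)c3)CC2)o1` gives 201 nM, the only number so far, so it has no numeric rank. Compound 3 `CCc1nc(-c2ccc(F)cc2)c(C(=O)N2CCN(c3cccc(OC)c3)CC2)o1` differs from compound 2 by one change: 4-fluorophenyl in place of 3-fluorophenyl on an aromatic carbon. Going by the values given here, no measured pair shows this change, so no size can be drawn from the data and no shift beyond the scatter is expected, in either direction. The estimated step of a 1.2-fold higher number from compound 2 to compound 3 (0.09 log units; within the scatter) is expected to stay within the usual scatter. For compound 3 the expected value is 250 nM, with an estimated range of 80 nM to 800 nM.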

Compound 3, half-maximal inhibitory concentration: 411 nM
The estimate for compound 3 lay 1.6-fold (0.22 log units) below the measured number; low and high end bracket the measured number.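

In this assay, for the compounds shown here, moving the fluorine on the phenyl group gives a 2.0-fold higher number from compound 2 to compound 3 (0.31 log units; beyond the scatter), the first measured step at this position, next to the ring nitrogen. The position therefore responds modestly to where the fluorine sits, with 3-fluorophenyl giving the lower number. No available data explain this step.

From the compounds shown here alone, whether unsubstituted phenyl or a chlorophenyl group would fall on either side of this pair remains open. Going by these compounds, it is also open whether the same order holds with a propyl chain in place of the ethyl group.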